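A few compounds are considered here, and "the series" means these few. Any claim that something is new, unique, unknown or untested is made for them only; others in the source may bear on it.

Three compounds of one series have numbers in an in vitro functional assay on cells for agonist activity at Bombesin receptor subtype-3 (Homo sapiens), read by luminescence and calcium flux; on this read-out lower numbers stand for an effect already at smaller amounts and higher numbers for an effect only at larger amounts of compound. Compound 1 `CCCCc1cnc(CCCc2ccc(-c3ccccc3C(=O)O)cc2)[nH]1` gives 5600 nM, compound 2 `CCCCc1cnc(C(Cc2ccc(-c3ccccc3C(=O)O)cc2)C(C)C)[nH]1` gives 4620 nM, and compound 3 `O=C(O)c1ccccc1-c1ccc(CCc2ncc(Cc3ccccc3Cl)[nH]2)cc1` gives 292 nM, the lowest of the three and beyond the scatter from both others. Compound 4 `O=C(O)c1ccccc1-c1ccc(CCc2ncc(CCC3CCCCC3)[nH]2)cc1` is not yet measured; it differs from compound 3 in one place: cyclohexylmethyl in place of 2-chlorophenyl on a saturated chain carbon bound to an aromatic carbon. Within the data shown here, the only guide is that the saturated butyl chains of compound 1 and compound 2 go with far higher numbers than the aromatic group of compound 3, so a moderate rise is expected for the step of a 2.7-fold higher number from compound 3 to compound 4 (0.44 log units; beyond the scatter). Compound 4 is estimated at 800 nM, between 250 nM and 3000 nM.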

Compound 4, half-maximal effective concentration: 642 nM
Estimate against measurement, compound 4: 1.2-fold (0.10 log units) above; the measured number falls inside the stated range.
By their numbers in this assay, from the lowest: compound 3; then compound 4; then compounds 2 and 1 (each within the scatter of the next).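

Replacing 2-chlorophenyl with cyclohexylmethyl on a saturated chain carbon bound to an aromatic carbon gives a 2.2-fold higher number from compound 3 to compound 4 (0.34 log units; beyond the scatter), a modest step that is still beyond the usual scatter. An aromatic ring at this position is therefore not essential, since compound 4 carries a non-aromatic ring of carbon only and the number rises only modestly. No measurement shown here explains the rise.

Open, as far as these compounds go, is how a plain benzyl group, without the chlorine, would compare. That comparison would separate the loss of chlorine from the loss of the aromatic ring.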